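Fluoro for methoxy on the sulfanyl phenyl of compound 3

The compounds below may be only part of what the source reports. "The series", "measured", "known", "first", "only" and "open" are said of these compounds alone.

Compound 3 `COc1ccc(Sc2nc3cc(N)cc(N)c3nc2-c2ccccc2)cc1` stands only at a limit in a functional assay on OVCAR-3 cells (Homo sapiens) for inhibition, read by sulforhodamine B assay, with a stated time of 48 h; a higher number here means a weaker inhibitor of growth, a lower number a stronger inhibitor of growth: in this assay compound 3 gives < 100000 nM, a limit rather than a number. That limit, (the limit of < 100000 nM in this assay, at which 1 of the 3 values shown sits), also leaves the step that the limit leaves unreadable from compound 2 to compound 3 unreadable. Compound 2 `Nc1cc(N)c2nc(-c3ccccc3)c(NCc3ccc(F)cc3)nc2c1` gives 6460 nM in this assay. Compound 1 `CCOC(=O)[C@H](CCC(=O)O)NC(=O)c1ccc(Oc2nc3cc(N)cc(N)c3nc2-c2ccccc2)cc1` gives 40700 nM in this assay. Compound 4 `Nc1cc(N)c2nc(-c3ccccc3)c(Sc3ccc(F)cc3)nc2c1` differs from compound 3 by fluoro in place of methoxy on an aromatic carbon. For the measured compounds named here, no measured step covers this exchange, and the one step touching compound 3 cannot be read, so no direction beyond the scatter is expected; the guess rests on where compounds 1 and 2 fall. Compound 4 is expected to give 30000 nM in this assay, within 6000 nM to 100000 nM. The step that the limit leaves unreadable from compound 3 to compound 4 is therefore only estimated against a limit.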

Compound 4, concentration for total growth inhibition: 33900 nM
The estimate for compound 4 lay 1.1-fold (0.05 log units) below the measured number, and the stated range covers the measured number.
By their numbers in this assay, from the lowest: compound 2; then compounds 4 and 1 (each within the scatter of the next).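

In this assay, for the compounds shown here, (4-fluorophenyl)sulfanyl in place of (4-fluorobenzyl)amino gives the first readable step for a sulfanyl group at this position: a 5.2-fold higher number from compound 2 to compound 4 (0.72 log units; beyond the scatter). On this one pair, the amino-linked group stays ahead of the sulfanyl-linked group. Compound 3 stands only at a limit, so the effect of fluoro in place of methoxy and the step to compound 3 cannot be read: the limit of < 100000 nM in this assay, at which 1 of the 4 values shown sits.

The step to compound 4 changes both the linking atom and the benzyl chain, so these two changes stay unseparated. A (4-fluorobenzyl)sulfanyl group or a (4-fluorophenyl)amino group would pull them apart.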